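The compounds below may be only part of what the source reports. "The series", "measured", "known", "first", "only" and "open" are said of these compounds alone.

Measured compounds:
- compound 1 `CN(C)C(=O)c1cc2cnc(Nc3ccc(NC(=O)C4(C(=O)Nc5cccc(Cl)c5)CC4)cc3)nc2n1C1CCCC1` — 8.3%
- compound 2 `CN(C)C(=O)c1cc2cnc(Nc3ccc(NC(=O)C4(C(=O)Nc5cccc(Br)c5)CC4)cc3)nc2n1C1CCCC1` — 20.2%

In a functional assay on A549 cells (Homo sapiens) for inhibition, read by CCK-8 assay, with a stated time of 72 h, tested at 1 uM (a higher number here means more inhibition of growth at the concentration tested, a lower number less inhibition of growth), compound 1 gives 8.3%, the lower of the two numbers shown. Going by the values given here, its only neighbour, compound 2, gives 20.2%, and the single step between them, a number 11.9 percentage points higher from compound 1 to compound 2 (beyond the scatter), is modest yet beyond the scatter. Compound 3 `COC(=O)c1cccc(NC(=O)C2(C(=O)Nc3ccc(Nc4ncc5cc(C(=O)N(C)C)n(C6CCCC6)c5n4)cc3)CC2)c1` is reached from compound 1 by one change: methoxycarbonyl in place of chloro on an aromatic carbon. Among the compounds with values here, the sole measured step, a number 11.9 percentage points higher from compound 1 to compound 2 (beyond the scatter), concerns an exchange of one halogen for another at the same aromatic carbon and so touches the same position, but it says nothing about a methoxycarbonyl group; no measured pair addresses that group. Both numbers sit low, so the step from compound 1 to compound 3 in this assay is expected to be small, without a clear direction, and likely within the scatter. Compound 3 is therefore estimated at 12%, with a range from 0% to 30%. That estimate corresponds to an expected step of a number 3.7 percentage points higher from compound 1 to compound 3 (within the scatter).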

Compound 3, percent growth inhibition at one concentration: 10.5%
Estimate against measurement, compound 3: 1.5 percentage points above; the measured number falls inside the stated range.
By their numbers in this assay, from the lowest: compounds 1, 3 and 2 (each within the scatter of the next, the first and the last beyond it).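

The exchange of chloro for methoxycarbonyl, which puts 4 heavy atoms and 2 hydrogen-bond acceptors in place of a single chlorine on the aromatic carbon, amounts in this assay to a number 2.2 percentage points higher from compound 1 to compound 3 (within the scatter). Set against the bromo compound, the same position gives a number 9.7 percentage points lower from compound 2 to compound 3 (within the scatter), so methoxycarbonyl cannot be told apart from either halogen, even though the two halogen compounds are separated from each other. Nothing available explains why this larger group reads so much like the halogens.

As far as these compounds go, whether an amine or a carboxylic acid on this aromatic carbon would differ from these three compounds remains open. So does whether methoxycarbonyl would read the same way on another carbon of this ring, since every substituent shown sits meta to the large group.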